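Swapping the pyrazole for a trimethoxyphenyl amine

A few compounds are considered here, and "the series" means these few. Any claim that something is new, unique, unknown or untested is made for them only; others in the source may bear on it.

Compound 2 `Cc1ccc(CNC(=O)c2cccc(C(C)Oc3ccnc(Nc4cnn(CC(C)(C)O)c4)c3)c2)cc1` sits at the edge of what can be read: in a functional assay on NCI-H3122 cells (Homo sapiens) for antiproliferative activity, read by MTT assay, with a stated time of 48 h (a higher number here means a weaker inhibitor, a lower number a stronger inhibitor), compound 2 gives only a limit, > 100000 nM. Its neighbour compound 1 `Cc1ccc(CNC(=O)c2cccc(C(C)Oc3ccnc(Nc4cnn(C5CCN(C)CC5)c4)c3)c2)cc1` carries a 1-methylpiperidin-4-yl on the pyrazole nitrogen instead, and in this assay compound 1 gives 8900 nM; the change to compound 2 is an at least 11-fold higher number from compound 1 to compound 2 (1.05 log units; beyond the scatter), so the group on that aromatic nitrogen weighs heavily, with one of the two values resting at the limit of > 100000 nM in this assay, at which 1 of the 2 values shown sits.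

Compound 3 `COc1cc(Nc2cc(OC(C)c3cccc(C(=O)NCc4ccc(C)cc4)c3)ccn2)cc(OC)c1OC` departs from compound 2 by 3,4,5-trimethoxyphenyl in place of 1-(2-hydroxy-2-methylpropyl)-1H-pyrazol-4-yl on a nitrogen on an aromatic ring. Within the data shown here, no measured pair covers a change of this kind, so the single measured step only shows how much a change at this part of the shared core can move the number; its direction for compound 3 is not given by the data. From the limit for compound 2, any real number for compound 3 would be a move downward, and the expected step is an at least 12-fold lower number from compound 2 to compound 3 (1.09 log units; beyond the scatter). Compound 3 is therefore estimated at 8000 nM in this assay, within 800 nM to 100000 nM.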

Compound 3, half-maximal inhibitory concentration: 7800 nM
For compound 3 the middle estimate is 1.0-fold (0.01 log units) above the measured one; the range from low to high includes it.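

With the 3,4,5-trimethoxyphenyl on the nitrogen on the aromatic ring, this assay shows an at least 12-fold lower number from compound 2 to compound 3 (1.10 log units; beyond the scatter), so a pyrazole is not needed at this place for a measurable number. Compound 2 gives only a limit here, and the size of that step rests on it: the limit of > 100000 nM in this assay, at which 1 of the 3 values shown sits.

The comparison with the other pyrazole gives a 1.1-fold lower number from compound 1 to compound 3 (0.06 log units; within the scatter), so the 3,4,5-trimethoxyphenyl and the 1-(1-methylpiperidin-4-yl)-1H-pyrazol-4-yl cannot be told apart in this read-out, even though one is a six-membered aromatic ring of carbon only and the other a five-membered aromatic ring with hetero atoms, and of the three compounds only compound 2 stands apart.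

The compounds shown leave open which part of the 3,4,5-trimethoxyphenyl matters, something an unsubstituted phenyl or a phenyl with a single methoxy would help to separate. Also open, as far as these compounds go, is whether a pyrazole with a plain methyl or a morpholine-bearing chain on its nitrogen would fall with compound 1 and compound 3 or with compound 2.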